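The source may hold more compounds than are shown below. What is called first, only, known or untested is meant among the compounds shown, and "the series" means these compounds.

Compound 1 has the structure `COc1cc(N)c(Cl)cc1NC(=O)C1CCN(Cc2ccccc2Cl)CC1`; in a functional assay on the whole organism for antagonist activity, with Mus musculus as the target (on this read-out lower numbers stand for an effect already at smaller amounts and higher numbers for an effect only at larger amounts of compound), compound 1 reaches only a limit of the assay, > 4 mg/kg.
Compound 2 has the structure `COc1cc(N)c(Cl)cc1NC(=O)C1CCN(CC2CCCC2)CC1`; in this assay compound 2 likewise reaches only a limit, > 10 mg/kg.
Compound 3 has the structure `COc1cc(N)c(Cl)cc1NC(=O)C1CCN(Cc2ccc([N+](=O)[O-])cc2)CC1`; in this assay compound 3 also stops at a limit, > 4 mg/kg.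

Compound 1 therefore stands nowhere that can be placed on a number: all three values are limits, two at the limit of > 4 mg/kg in this assay, at which 2 of the 3 values shown sit, and one at the limit of > 10 mg/kg in this assay, at which 1 of the 3 values shown sits. The two measured steps that start from compound 1 are a step that the two limits leave unreadable from compound 1 to compound 2 and a step that the two limits leave unreadable from compound 1 to compound 3, and the third, a step that the two limits leave unreadable from compound 2 to compound 3, is no clearer. None of them carries a readable size or direction.

Compound 4, `COc1cc(N)c(Cl)cc1NC(=O)C1CCN(C2CCCC2)CC1`, is not yet measured. Compared with compound 1 the change is cyclopentyl in place of 2-chlorobenzyl on an amine nitrogen in a ring: the group that leaves is the 2-chlorobenzyl, the group that enters is the cyclopentyl, and it sits on the amine nitrogen in the six-membered non-aromatic ring. The measured steps bear on this change only in that none of them produced a numbered value, so no size or direction beyond the scatter can be expected from them. Compound 4 is accordingly expected to give 10 mg/kg, in a range from 4 mg/kg to 30 mg/kg, most likely again as a limit. The step that the limit leaves unreadable from compound 1 to compound 4 is the estimated consequence.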

Compound 4, dose for half-maximal effect: > 10 mg/kg
Compound 4: a limit, no number (the forecaster's own chance of this, stated with the estimate: 80%); the middle value sits exactly at the limit.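

Compound 4 also stops at a limit, so the steps to it from compound 1 and from compound 2 cannot be read in size or direction. The compounds shown leave open whether any group on the amine nitrogen in the ring gives a numbered value in this assay.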